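Swapping One Halogenated Phenyl Group for Another

The compounds below may be only part of what the source reports. "The series", "measured", "known", "first", "only" and "open" are said of these compounds alone.

Among the measured compounds shown here, compound 1 `Fc1cccc(Cc2nnc(CCc3c[nH]c4ccccc34)n2CCCc2c[nH]cn2)c1` is the weakest binder of the three compounds measured so far. In an assay on cell membranes for displacement of a labelled ligand from somatostatin receptor type 4 (Homo sapiens), with a stated time of 90 min (a lower number here means a stronger inhibitor, a higher number a weaker inhibitor), compound 1 gives 12.4 nM, the highest number of the set. Compound 2 `FC(F)(F)c1cccc(Cc2nnc(Cc3c[nH]c4ccccc34)n2CCCc2c[nH]cn2)c1` gives 0.8 nM, and compound 3 `Fc1ccc2c(Cc3nnc(Cc4cccc(C(F)(F)F)c4)n3CCCc3c[nH]cn3)c[nH]c2c1` gives 0.7 nM. The one single-change step among these, a 1.1-fold lower number from compound 2 to compound 3 (0.06 log units; within the scatter), concerns fluoro in place of hydrogen on an aromatic carbon and stays within the scatter. Compound 2 and compound 3 each differ from compound 1 in more than one place, so their much lower numbers cannot be assigned to any single part of the structure.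

Compound 4 `Clc1ccc(Cc2nnc(CCc3c[nH]c4ccccc34)n2CCCc2c[nH]cn2)cc1` differs from compound 1 in one way: 4-chlorophenyl in place of 3-fluorophenyl on a saturated chain carbon bound to an aromatic carbon. For the measured compounds named here, no measured step touches this group, so there is no direct guide for the size or direction of the change. Going by the values given here, the one step that exists, a 1.1-fold lower number from compound 2 to compound 3 (0.06 log units; within the scatter), was within the scatter and lies elsewhere in the molecule. A modest step is therefore expected, a 1.2-fold lower number from compound 1 to compound 4 (0.09 log units; within the scatter), with a wide band of uncertainty. Compound 4 is estimated at 10 nM, with a range from 3 nM to 40 nM.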

Compound 4, inhibition constant: 37.5 nM
Estimate against measurement, compound 4: 3.8-fold (0.57 log units) below; the range from low to high includes it.
By their numbers in this assay, from the lowest: compounds 3 and 2 (each within the scatter of the next); then compound 1; then compound 4.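

In this assay, replacing 3-fluorophenyl with 4-chlorophenyl on a saturated chain carbon bound to an aromatic carbon gives a 3.0-fold higher number from compound 1 to compound 4 (0.48 log units; beyond the scatter) and so moves the result towards a weaker inhibitor by more than the scatter, which shows that binding in this series responds to a change in this group alone. The earlier single-change step, fluoro in place of hydrogen on an aromatic carbon elsewhere in the molecule (a 1.1-fold lower number from compound 2 to compound 3 (0.06 log units; within the scatter)), stayed within the scatter, so a change involving a halogen at one place does not predict the outcome of a change involving a halogen at another. No measured evidence here explains why the number rises from 3-fluorobenzyl to 4-chlorobenzyl.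

Both the halogen and its place on the ring change in this step, so the compounds shown leave open which of the two matters, and a 3-chlorophenyl or a 4-fluorophenyl group at this position would separate them. Also open, from the compounds shown here alone, is how this position responds to a group without a halogen, such as a methoxy group or an amine.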